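Cinnamoyl oxadiazoline series: expectation for the methoxyphenyl analogue

The compounds below may be only part of what the source reports. "The series", "measured", "known", "first", "only" and "open" are said of these compounds alone.

Measured so far in an ADME assay on PANC-1 cells (Homo sapiens) for cytotoxicity, read by MTT assay, with a stated time of 48 h; on this read-out lower numbers stand for stronger inhibition of growth and higher numbers for weaker inhibition of growth:
compound 1, `O=C(/C=C\c1cccc(O)c1)N1N=C(c2ccncc2)OC1c1c[nH]c2ccccc12`: > 30 ug/mL
compound 2, `O=C(/C=C\c1ccccc1[N+](=O)[O-])N1N=C(c2ccncc2)OC1c1c[nH]c2ccccc12`: > 30 ug/mL
compound 3, `O=C(/C=C\c1cccc([N+](=O)[O-])c1)N1N=C(c2ccncc2)OC1c1c[nH]c2ccccc12`: > 30 ug/mL

Every value above is a limit of this assay and not a number. Compound 3 stands at the limit > 30 ug/mL, as do the other two compounds: the limit of > 30 ug/mL in this assay, at which 3 of the 3 values shown sit. The steps between them are therefore not readable: a step that the two limits leave unreadable from compound 1 to compound 2, a step that the two limits leave unreadable from compound 1 to compound 3 and a step that the two limits leave unreadable from compound 2 to compound 3. Nothing within the measured set separates a hydroxy from a nitro substituent, nor one ring position from another, in this assay.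

Compound 4, `COc1ccc(/C=C\C(=O)N2N=C(c3ccncc3)OC2c2c[nH]c3ccccc23)cc1`, is not yet measured. The change from compound 3 is 4-methoxyphenyl in place of 3-nitrophenyl on a double-bonded chain carbon bound to a double-bonded chain carbon. Among the measured steps, the ones that bear on it are those that exchange the substituent on the phenyl ring, a step that the two limits leave unreadable from compound 1 to compound 3, and those that move it around the ring, a step that the two limits leave unreadable from compound 2 to compound 3; both are unreadable in size, and all three compounds sit at the same limit. No direction can be read from them.

Compound 4 is accordingly expected to remain at or near the assay ceiling, with an estimated value of 40 ug/mL and a range from 12 ug/mL to 120 ug/mL. The expected step from compound 3 to compound 4 is a step that the limit leaves unreadable from compound 3 to compound 4, most likely again reported only as a limit.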

Compound 4, concentration for 50% growth inhibition: > 30 ug/mL
Compound 4: no number, only a limit (the forecaster's own chance of this, stated with the estimate: 75%); the middle value lies beyond the limit too.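

In this assay compound 4 gives > 30 ug/mL, a limit and not a number. No step from compound 1, compound 2 or compound 3 to compound 4 can be read, as all four compounds share one limit: the limit of > 30 ug/mL in this assay, at which 4 of the 4 values shown sit.

Still open, going by these compounds, is whether any substituent on this phenyl ring would give a measured number in this assay.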